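Adding dimethylamino to compound 2

This account rests on a few compounds, and the source may have more. Where it says the series, first, only, none or still open, it means among the compounds named here.

- compound 1 `COc1ccc(/C=C2\CCC/C(=C\c3cccc([N+](=O)[O-])c3)C2=O)cc1` gives 4800 nM
- compound 2 `O=C1/C(=C/c2ccccc2)CCC/C1=C\c1ccc([N+](=O)[O-])cc1` gives 4900 nM

In a functional assay on HSC-2 cells (Homo sapiens) for cytotoxicity, with a stated time of 24 h (a higher number here means that more compound is tolerated, a lower number that less compound is tolerated), compound 2 (4900 nM) stands level with compound 1 (4800 nM), the two values lying within the usual scatter of each other. Within the data shown here, these two compounds differ in more than one place, so the measurements offer no single-change step to serve as a guide.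

Compound 3 `CN(C)c1ccc(/C=C2\CCC/C(=C\c3ccc([N+](=O)[O-])cc3)C2=O)cc1` has not yet been measured. Compared with compound 2, it has dimethylamino in place of hydrogen on an aromatic carbon, para to a large group (dimethylamino in place of hydrogen on an aromatic carbon). This amounts to a change from phenyl to 4-(dimethylamino)phenyl.

Among the measured compounds shown here, nothing measured so far in this assay shows what such a change does, so no step beyond the scatter is expected, and no direction is favoured. The expected step runs a 1.1-fold higher number from compound 2 to compound 3 (0.05 log units; within the scatter) (an estimate only). Compound 3 is estimated at 5500 nM (expected range 1800 nM to 16000 nM).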

Compound 3, half-maximal cytotoxic concentration: 11000 nM
Beside the measured number, compound 3's estimate is 2.0-fold (0.30 log units) below it, and the stated range covers the measured number.
By their numbers in this assay, from the lowest: compounds 1 and 2 (each within the scatter of the next); then compound 3.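

Dimethylamino in place of hydrogen on an aromatic carbon, para to a large group, gives a 2.2-fold higher number from compound 2 to compound 3 (0.35 log units; beyond the scatter) in this assay, the first single-change step available in this set. This position on the phenyl of compound 2 is therefore not silent: the change moves the read-out beyond the scatter, though only modestly, and towards more compound being tolerated. Nothing available bears on the cause of this step.

The compounds shown leave open whether the rise belongs to dimethylamino itself or would also come with another group at this place, such as a primary amine, a carboxylic acid or diethylamino. One step on one background also leaves open whether the same change would act alike with the nitro group placed as in compound 1.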